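Fluoro to bromo on the phenylpiperazine end: compound 4

A few compounds are considered here, and "the series" means these few. Any claim that something is new, unique, unknown or untested is made for them only; others in the source may bear on it.

Measured so far:
compound 1 `N#Cc1ccc(N2CCN(S(=O)(=O)c3ccc4c(c3)CC(=O)N4)CC2)cc1` — 2910 nM
compound 2 `O=C1Cc2cc(S(=O)(=O)N3CCN(c4ccc([N+](=O)[O-])cc4)CC3)ccc2N1` — 3660 nM
compound 3 `O=C1Cc2cc(S(=O)(=O)N3CCN(c4ccc(F)cc4)CC3)ccc2N1` — "not active" (no number reported)

In an assay on isolated protein for inhibition of lysosomal alpha-glucosidase (Homo sapiens), read by fluorescence, with stated times of 5 min and 45 min (on this read-out lower numbers stand for stronger inhibition and higher numbers for weaker inhibition), compound 1 gives 2910 nM and compound 2 gives 3660 nM. Going by the values given here, the one single-point step, nitro in place of cyano on an aromatic carbon, reads a 1.3-fold higher number from compound 1 to compound 2 (0.10 log units; within the scatter) and so shows no change beyond the scatter. In this assay compound 3 is reported as "not active" (no number reported), with no number; it cannot be placed on the scale of compounds 1 and 2, only set apart from them as having no measured value.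

Compound 4 `O=C1Cc2cc(S(=O)(=O)N3CCN(c4ccc(Br)cc4)CC3)ccc2N1` differs from compound 3 by bromo in place of fluoro on an aromatic carbon. Among the compounds with values here, no measured step bears on this change: the step from compound 1 to compound 2 concerns a different exchange and was within the scatter, and compound 3 offers no number to step from. No direction can therefore be expected in this assay beyond the scatter. Compound 4 is estimated at 6000 nM, within 1500 nM to 30000 nM, with a sizeable chance that, like compound 3, only an inactive report results.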

Compound 4, half-maximal inhibitory concentration: "not active" (no number reported)
Compound 4 has no reported number here, and the estimate cannot be compared.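

Compound 3 and compound 4 both carry only a "not active" report, so no step can be read between them. Nothing available bears on this result. Where either compound stands relative to compound 1 and compound 2 stays open, as does any difference between fluoro and bromo.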